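A few compounds are considered here, and "the series" means these few. Any claim that something is new, unique, unknown or untested is made for them only; others in the source may bear on it.

Compound 3, whose structure is `Cc1ccc(N2C(=O)C/C(=C\c3cccc(C(=O)Nc4cccc(F)c4)c3)C2=O)cc1`, is one of three compounds of the shared core so far examined in an ADME assay on NCM460 cells (Homo sapiens) for cytotoxicity, read by MTT assay, with a stated time of 72 h; a lower number here means a stronger inhibitor, a higher number a weaker inhibitor. In this assay compound 3 gives > 100000 nM, which is a limit of the assay and not a number. Its two companions stand in the same place. Compound 1, with structure `Cc1ccc(NC(=O)c2cccc(/C=C3\CC(=O)N(c4ccccc4)C3=O)c2)cc1`, gives > 100000 nM in this assay, again a limit. Compound 2, with structure `CCc1ccc(NC(=O)c2cccc(/C=C3\CC(=O)N(c4ccccc4)C3=O)c2)cc1`, gives > 100000 nM in this assay, also a limit. Among the compounds with values here, the one step that can be traced among them, a step that the two limits leave unreadable from compound 1 to compound 2, is therefore unreadable, and the only firm statement is the limit of > 100000 nM in this assay, at which 3 of the 3 values shown sit.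

Compound 4, with structure `Cc1ccc(N2C(=O)C/C(=C\c3cccc(C(=O)Nc4ccc(Cl)cc4)c3)C2=O)cc1`, differs from compound 3 by 4-chlorophenyl in place of 3-fluorophenyl on an amide-type nitrogen. Within the data shown here, no measured step speaks directly to this change, and the three values seen so far give no foothold for a readable movement in either direction. The step from compound 3 to compound 4 is therefore expected to be a step that the limit leaves unreadable from compound 3 to compound 4, that is, none beyond the scatter. For compound 4 the estimate in this assay is 150000 nM, within a range of 60000 nM to 400000 nM, with the strong likelihood that the assay again reports only a limit.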

Compound 4, half-maximal inhibitory concentration: > 100000 nM
Compound 4: no number, only a limit (the forecaster's own chance of this, stated with the estimate: 85%); the middle value does not contradict the limit.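

In this assay compound 4 gives > 100000 nM, a limit and not a number. Compound 3 also stands at a limit, and the change between compound 3 and compound 4 cannot be read. The compounds shown leave open whether any change to the shared core would give a measurable value in this assay.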